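The compounds below may be only part of what the source reports. "The series", "measured", "known", "first", "only" and "open" are said of these compounds alone.

Compound 1 `C#Cc1ccc(CCC(=O)O)cc1` — > 100000 nM, a limit of the assay.
Compound 2 `C/C=C(/C)C#Cc1ccc(CCC(=O)O)c(F)c1` — 20.4 nM; 20 nM (2 entries).
Compound 3 `C/C=C\C#Cc1ccc(CCC(=O)O)c(F)c1` — 47.9 nM.

In a functional assay on 1321-N1 cells for agonist activity at Free fatty acid receptor 1 (Homo sapiens), read by calcium flux, with a stated time of 0.4 s (a lower number here means that less compound is needed, a higher number that more compound is needed for the effect), compound 3 gives the only single number among the three results shown; compound 2 has two entries (the several entries of compound 2 in this assay, 20.4 nM; 20 nM (2 entries)), and compound 1 has only a limit (the limit of > 100000 nM in this assay, at which 1 of the 3 values shown sits). Compound 4 `C/C=C(\C)C#Cc1ccc(CCC(=O)O)c(F)c1` differs from compound 3 by 1-methylprop-1-en-1-yl in place of prop-1-en-1-yl on a triple-bonded carbon. Compound 2 carries the same group as compound 4, in another geometry of the double bond, and its values sit a little below those of compound 3, a gap within the usual scatter. The expected step of a 1.9-fold lower number from compound 3 to compound 4 (0.28 log units; within the scatter) is therefore small, toward less compound needed, and may not exceed the scatter. Compound 4 is expected to give 25 nM, between 10 nM and 60 nM.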

Compound 4, half-maximal effective concentration: 37.2 nM
Compound 4: the middle estimate sits 1.5-fold (0.17 log units) below what was measured; measured number inside the range.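

Replacing prop-1-en-1-yl with 1-methylprop-1-en-1-yl on a triple-bonded carbon gives a 1.3-fold lower number from compound 3 to compound 4 (0.11 log units; within the scatter) in this assay, so this position accepts the extra carbon with no shift that stands clear of the scatter. Compound 2 gives 20.4 nM; 20 nM (2 entries) and compound 4 gives 37.2 nM, which puts both geometries of the double bond on view as a comparison of one feature: the fact that compounds 2 and 4 differ only in the configuration as drawn

From the compounds shown here alone, whether this tolerance extends to a longer chain at this place remains open. So does the effect of a group carrying an amine or a hydroxyl there.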